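Dropping the Amino Link on the Carbonyl Carbon

The source may hold more compounds than are shown below. What is called first, only, known or untested is meant among the compounds shown, and "the series" means these compounds.

Compound 2, `COc1cc(Cl)cc(-c2nn(-c3cccc(NC(=O)Nc4ccc(Cl)c(C(F)(F)F)c4)c3)cc2-c2ccncc2)c1`, stands lowest of the three numbers in a functional assay on SF-539 cells (Homo sapiens) for inhibition, read by sulforhodamine B assay, with a stated time of 48 h, tested at 10 uM (on this read-out lower numbers stand for a stronger effect and higher numbers for a weaker effect at the one concentration tested), where compound 2 gives -1.17%. Among the compounds with values here, its nearest neighbour, compound 1, `COc1cc(Cl)cc(-c2nn(-c3cccc(NC(=O)Nc4cccc(C(F)(F)F)c4)c3)cc2-c2ccncc2)c1`, gives 17%; the only single-point step, a number 18.2 percentage points lower from compound 1 to compound 2 (beyond the scatter), concerns a chloro in place of hydrogen and does not touch the change considered here. Compound 3, `COc1cc(Cl)cc(-c2nn(-c3cccc(NC(=O)c4cc(C(F)(F)F)cc(C(F)(F)F)c4)c3)cc2-c2ccncc2)c1`, has no amino link on its carbonyl carbon and gives 80%. Compound 4, `COc1cc(Cl)cc(-c2nn(-c3cccc(NC(=O)c4ccc(Cl)c(Cl)c4)c3)cc2-c2ccncc2)c1`, arises from compound 2 by 3,4-dichlorophenyl in place of (4-chloro-3-(trifluoromethyl)phenyl)amino on a carbonyl carbon, likewise losing the amino link. Within the data shown here, no single-point step covers this change, so the expectation rests on compound 3 and its value 80%. Compound 4 is expected to rise by a number 61.2 percentage points higher from compound 2 to compound 4 (beyond the scatter), to an estimated 60% within 25% to 95%.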

Compound 4, a percentage reported as activity, at one concentration (the size of the read-out at that concentration, not a potency): 74.5%
Compound 4: middle estimate off by 14.5 percentage points, on the low side; low and high end bracket the measured number.
By their numbers in this assay, from the lowest: compound 2; then compound 1; then compounds 4 and 3 (each within the scatter of the next).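

In this assay, the step of a number 75.7 percentage points higher from compound 2 to compound 4 (beyond the scatter) shows that 3,4-dichlorophenyl on this carbonyl carbon, in place of (4-chloro-3-(trifluoromethyl)phenyl)amino, removes nearly all of the effect, and the step of a number 57.5 percentage points higher from compound 1 to compound 4 (beyond the scatter) shows a similar loss against (3-(trifluoromethyl)phenyl)amino. Compound 3 and compound 4 both lack the amino link and both show a weak effect despite different ring substituents, so compound 3 is no longer a lone case. No measured evidence explains this loss.

Going by these compounds, each step changes the amino link and the ring substituents together, so their separate contributions stay open. On these data alone, it also remains open how an oxygen or a methylene in place of the amino link would behave.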